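A few compounds are considered here, and "the series" means these few. Any claim that something is new, unique, unknown or untested is made for them only; others in the source may bear on it.

In an ADME assay on 2209-23 cells (Homo sapiens) for cytotoxicity, read by WST assay and thymidine incorporation (a higher number here means that more compound is tolerated, a lower number that less compound is tolerated), the measured compounds so far are:

Compound 1 `CC(C)(C)CCN1C(=O)C(C2=CS(=O)(=O)c3cc(NS(C)(=O)=O)ccc3N2)=C(O)[C@@H]1C(C)(C)C`: > 50000 nM
Compound 2 `CC(=O)C1=C(C2=C(O)[C@H](C(C)(C)C)N(Cc3ccc(F)cc3)C2=O)Nc2ccc(NS(C)(=O)=O)cc2S1(=O)=O`: > 50000 nM

Both entries are limits of the assay and not numbers. Compound 2 therefore has no exact position on the scale, and its result is > 50000 nM, which is a limit. The data so far consist only of the limit of > 50000 nM in this assay, at which 2 of the 2 values shown sit. Within the data shown here, there is no exact value to compare, and no measured pair shows how a single structural change affects this read-out.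

The next compound is compound 3 `CC(C)(C)[C@H]1C(O)=C(C2=CS(=O)(=O)c3cc(NS(C)(=O)=O)ccc3N2)C(=O)N1Cc1ccc(F)cc1`, which differs from compound 2 at one place: hydrogen in place of acetyl on a double-bonded ring carbon. In words, this is hydrogen in place of acetyl on a double-bonded ring carbon.

With nothing measured below the limit, no direction of change can be argued from the data. The step of a number no higher from compound 2 to compound 3 (the limit leaves the size open) is expected to stay within the usual scatter in this assay. The estimate for compound 3 is 50000 nM, with an expected range from 25000 nM to 100000 nM. The result may well arrive as a limit rather than a number.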

Compound 3, half-maximal cytotoxic concentration: > 50000 nM
Compound 3 ended at the assay's limit (the forecaster's own chance of this, stated with the estimate: 85%); the middle value lies on the limit itself.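

In this assay compound 3 gives > 50000 nM, which is a limit of the assay and not a number. The steps from compound 1 and compound 2 to compound 3 therefore cannot be read: the limit of > 50000 nM in this assay, at which 3 of the 3 values shown sit. The compounds shown leave open whether hydrogen in place of acetyl, or 4-fluorophenyl in place of neopentyl, changes this read-out at all.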